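Chloro to nitro on a pair of level compounds

The compounds below may be only part of what the source reports. "The series", "measured", "known", "first", "only" and "open" are said of these compounds alone.

In a functional assay on HepG2 cells (Homo sapiens) for cytotoxicity, read by MTT assay, with a stated time of 48 h (on this read-out higher numbers stand for weaker inhibition and lower numbers for stronger inhibition), compound 1 `COc1ccc(/C=C2/S/C(=N/c3ccccc3)N(Cc3ccncc3)C2=O)cc1` gives 19100 nM and compound 2 `O=C1/C(=C\c2ccc(Cl)cc2)S/C(=N/c2ccccc2)N1Cc1ccncc1` gives 28800 nM which places the two within the usual scatter of each other. Compound 3 `O=C1/C(=C\c2ccc([N+](=O)[O-])cc2)S/C(=N/c2ccccc2)N1Cc1ccncc1` differs from compound 2 by nitro in place of chloro on an aromatic carbon, para to a large group (nitro in place of chloro on an aromatic carbon). Within the data shown here, the one measured step that bears on this is a 1.5-fold higher number from compound 1 to compound 2 (0.18 log units; within the scatter) for chloro in place of methoxy, and it lies within the scatter. No step beyond the scatter is therefore expected in this assay for this swap. The expected change is a 1.3-fold lower number from compound 2 to compound 3 (0.12 log units; within the scatter) at this stage. For compound 3 the estimate is 22000 nM with 9000 nM to 50000 nM as the expected range.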

Compound 3, half-maximal inhibitory concentration: 18900 nM
The estimate for compound 3 lay 1.2-fold (0.07 log units) above the measured number, and the stated range covers the measured number.
By their numbers in this assay, from the lowest: compounds 3, 1 and 2 (each within the scatter of the next).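

On the aromatic carbon para to a large group, nitro in place of chloro gives (a 1.5-fold lower number from compound 2 to compound 3 (0.18 log units; within the scatter)), and nitro in place of methoxy gives (a 1.0-fold lower number from compound 1 to compound 3 (0.00 log units; within the scatter)). Chloro, methoxy and now nitro, which brings hydrogen-bond acceptors that chloro lacks, all leave the three compounds level in this assay. Nothing available explains this flat result. Still open, from the compounds shown here alone, is whether an amine or a carboxylic acid at this position, or a change elsewhere on the shared core, would move the number beyond the scatter.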